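The source may report more compounds than this note shows. Statements on the series, on what has been measured and on what is new or still open speak of the compounds shown alone.

Of the compounds shown here, two of this set have been measured in a functional assay on SGC-7901 cells (Homo sapiens) for antiproliferative activity, read by MTT assay, with a stated time of 24 h; a lower number here means a stronger inhibitor, a higher number a weaker inhibitor. Compound 1, `O=C(NNc1cccc(Cl)c1)c1ccc(NS(=O)(=O)c2cnc(O)nc2O)cc1`, gives 11600 nM there. Compound 2, `Cc1cccc(NNC(=O)c2cccc(NS(=O)(=O)c3cnc(O)nc3O)c2)c1`, returns only a limit of the assay, > 20000 nM, so its true value is not known. Going by the values given here, the one value and the one limit place the pair at the weak end, with the limit of > 20000 nM in this assay, at which 1 of the 2 values shown sits, showing where compound 2 sits.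

Compound 3, `O=C(NNC(=O)c1cccc(NS(=O)(=O)c2cnc(O)nc2O)c1)c1ccc(F)cc1`, has not yet been measured. It differs from compound 2 in one place: (4-fluorophenyl)carbonyl in place of 3-methylphenyl on an amine nitrogen. Among the compounds with values here, with no step between measured compounds to lean on, the expectation for the step of an at least 1.1-fold lower number from compound 2 to compound 3 (0.04 log units; that floor lies within the scatter) is that it is no larger than the usual scatter, in either direction. On that basis compound 3 is expected to show 18000 nM in this assay, with a range from 6000 nM to 50000 nM, and a real chance that only a limit is reported again.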

Compound 3, half-maximal inhibitory concentration: > 20000 nM
Compound 3: no number, only a limit (the forecaster's own chance of this, stated with the estimate: 50%); middle value at least 1.1-fold (0.04 log units) from the limit.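

Compound 3, like compound 2, returns only a limit in this assay, so no step can be read between these two compounds: the limit of > 20000 nM in this assay, at which 2 of the 3 values shown sit.

The compounds shown leave open where either true value lies, and whether (4-fluorophenyl)carbonyl in place of 3-methylphenyl on an amine nitrogen changes antiproliferative activity at all.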